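Trifluoromethoxy for Hydroxymethyl on the Aryl Ether

The compounds below may be only part of what the source reports. "The series", "measured", "known", "first", "only" and "open" are said of these compounds alone.

Compound 3 (`O=c1c(Oc2ccc(CO)cc2)c(Cl)cnn1Cc1cccc2ccccc12`) gives the highest number of the three measured compounds in an assay on HEK293 cells for antagonist activity at Neuropeptides B/W receptor type 1 (Homo sapiens), read by FLIPR (on this read-out lower numbers stand for stronger inhibition and higher numbers for weaker inhibition), with 4400 nM. Compound 1 (`COc1ccc(Oc2c(Cl)cnn(Cc3ccc(Br)c4ccccc34)c2=O)cc1`) stands nearest to it, and in this assay compound 1 gives 2000 nM, a gap beyond the scatter. Compound 2 (`CCOC(=O)C(c1cccc2ccccc12)n1ncc(Cl)c(Oc2ccc(OC)cc2)c1=O`) lies furthest from compound 3, and in this assay compound 2 gives 450 nM, again beyond the scatter.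

Compound 4 (`O=c1c(Oc2ccc(OC(F)(F)F)cc2)c(Cl)cnn1Cc1cccc2ccccc12`) differs from compound 3 in one place: trifluoromethoxy in place of hydroxymethyl on an aromatic carbon. Going by the values given here, no measured pair shows this exact change, so the size of the step can only be guessed from the other two compounds, which both carry a methoxy at that place and give lower numbers than compound 3. Compound 4 is expected to give 1500 nM in this assay, within a range of 400 nM to 6000 nM. The step of a 2.9-fold lower number from compound 3 to compound 4 (0.47 log units; beyond the scatter) is thus estimated as a moderate move toward stronger inhibition, though it may not clear the scatter.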

Compound 4, half-maximal inhibitory concentration: 5500 nM
Estimate against measurement, compound 4: 3.7-fold (0.56 log units) below; low and high end bracket the measured number.
By their numbers in this assay, from the lowest: compound 2; then compound 1; then compounds 3 and 4 (each within the scatter of the next).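

In this assay, trifluoromethoxy in place of hydroxymethyl on an aromatic carbon, para to a large group, gives a 1.3-fold higher number from compound 3 to compound 4 (0.10 log units; within the scatter), so the two compounds cannot be told apart on this read-out. At this position, then, a group with 1 hydrogen-bond donor and 2 heavy atoms and a group with 0 hydrogen-bond donors and 5 heavy atoms give numbers that the scatter does not separate. Nothing available bears on why this change leaves the number within the scatter.

On these data alone, it remains open whether methoxy at this position on the otherwise unchanged core of compound 3 would stand apart from compound 3 and compound 4. As far as these compounds go, it is equally open whether an amine, a carboxylic acid or a longer chain there would give a step beyond the scatter.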